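Pyrimidinyl amide in the pyridinylpiperazine acetamide series

This account rests on a few compounds, and the source may have more. Where it says the series, first, only, none or still open, it means among the compounds named here.

Going by the values given here, compound 2 `O=C(CN1CCN(c2ccccn2)CC1)Nc1cccnc1` gives 1080 nM in a functional assay on cells for agonist activity at D(4) dopamine receptor (Homo sapiens), read by TR-FRET and cAMP accumulation, with a stated time of 30 min (a lower number here means that less compound is needed, a higher number that more compound is needed for the effect), the highest of the two numbers so far; compound 1 `CCc1cccc(NC(=O)CN2CCN(c3ccccn3)CC2)c1` gives 28.7 nM. Among the compounds with values here, the only measured step, a 38-fold higher number from compound 1 to compound 2 (1.58 log units; beyond the scatter), was large. Compound 3 `O=C(CN1CCN(c2ccccn2)CC1)Nc1cncnc1` differs from compound 2 by pyrimidin-5-yl in place of pyridin-3-yl on an amide-type nitrogen. Within the data shown here, no measured step covers this exact change, but the one step at this amide-type nitrogen, 3-ethylphenyl to pyridin-3-yl, went toward a higher number, so a modest further rise beyond the scatter is expected, with wide uncertainty. Compound 3 is therefore estimated at 3000 nM, between 800 nM and 12000 nM. The expected step reads a 2.8-fold higher number from compound 2 to compound 3 (0.44 log units; beyond the scatter).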

Compound 3, half-maximal effective concentration: "not active" (no number reported)
Nothing numeric was reported for compound 3; the estimate stays without a comparison.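

Going by these compounds alone, compound 3 is reported as not active without a number in this assay, and no step from compound 2 to compound 3 can be read. The compounds shown leave open how far pyrimidin-5-yl in place of pyridin-3-yl moves the number. No measurement shown here bears on this result.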